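The source may report more compounds than this note shows. Statements on the series, on what has been measured and on what is new or still open speak of the compounds shown alone.

Working notes on the series, read in a functional assay on PC-3 cells (Homo sapiens) for antiproliferative activity, read by MTT assay, with a stated time of 48 h; on this read-out lower numbers stand for stronger inhibition and higher numbers for weaker inhibition. For the measured compounds named here, compound 1 (`COc1ccc(CN(C(=O)CSc2nc3ccccc3s2)c2cc(OC)c(OC)c(OC)c2)cc1O`) gives 2110 nM and compound 2 (`COc1ccc2nc(SCC(=O)N(Cc3ccc(OC)c(O)c3)c3cc(OC)c(OC)c(OC)c3)sc2c1`) gives 4110 nM, so compound 2 stands within the scatter of compound 1, the only other compound measured. Compound 3 (`COc1ccc(CN(C(=O)CSc2nc3cc(Cl)ccc3s2)c2cc(OC)c(OC)c(OC)c2)cc1O`) is not yet measured. Its difference from compound 2 is 5-chloro-1,3-benzothiazol-2-yl in place of 6-methoxy-1,3-benzothiazol-2-yl on a sulfur. Going by the values given here, the one measured step that bears on this is a 1.9-fold higher number from compound 1 to compound 2 (0.29 log units; within the scatter), for methoxy in place of hydrogen on an aromatic carbon. Among the compounds with values here, no chlorine-bearing compound has been measured, so that half of the change has no direct reference. Given the size of that single step, no move beyond the scatter is expected in this assay. The expected step is a 1.5-fold lower number from compound 2 to compound 3 (0.17 log units; within the scatter). For compound 3 the estimated value is 2800 nM, with an expected range of 1200 nM to 6500 nM.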

Compound 3, half-maximal inhibitory concentration: 11200 nM
Compound 3: middle estimate off by 4.0-fold (0.60 log units), on the low side; measured number above the stated range.
By their numbers in this assay, from the lowest: compounds 1 and 2 (each within the scatter of the next); then compound 3.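

In this assay, chloro in place of hydrogen on an aromatic carbon gives a 5.3-fold higher number from compound 1 to compound 3 (0.72 log units; beyond the scatter), a move beyond the scatter and so weaker inhibition, whereas methoxy in place of hydrogen gives only a 1.9-fold higher number from compound 1 to compound 2 (0.29 log units; within the scatter), within the scatter. Direct exchange of 6-methoxy-1,3-benzothiazol-2-yl for 5-chloro-1,3-benzothiazol-2-yl on the sulfur gives a 2.7-fold higher number from compound 2 to compound 3 (0.44 log units; beyond the scatter), also beyond the scatter, so this part of the molecule does not accept every change equally. No measurement offered here accounts for the difference between the two substituents.

The exchange alters both the substituent and its place in the name, so the effect of chlorine itself cannot be separated from that of its location. From the compounds shown here alone, whether an amine or a carboxylic acid on the 1,3-benzothiazol-2-yl group would hold the activity of compound 1 remains open.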